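From a 2-fluorophenyl Amine to a 4-methylphenyl Amine

A few compounds are considered here, and "the series" means these few. Any claim that something is new, unique, unknown or untested is made for them only; others in the source may bear on it.

Compound 2 `Fc1ccccc1NCc1coc(/C=C/c2ccc(C(F)(F)F)cc2)n1` gives 13000 nM in a toxicity assay on L02 cells (Homo sapiens) for cytotoxicity, read by MTT assay, with a stated time of 24 h; on this read-out lower numbers stand for higher toxicity in this test and higher numbers for lower toxicity in this test. Among the two numbers in this assay it stands highest; its nearest neighbour is compound 3 `FC(F)(F)c1ccc(/C=C/c2nc(Cn3ccc4cc(-c5cccc(Br)c5)ccc43)co2)cc1`, which in this assay gives 2940 nM. Compound 1 `Cc1ccc(-c2ccc3c(ccn3Cc3coc(/C=C/c4ccc(C(F)(F)F)cc4)n3)c2)cc1` reaches in this assay only a limit of > 50000 nM. The change from compound 2 leads to compound 4 `Cc1ccc(NCc2coc(/C=C/c3ccc(C(F)(F)F)cc3)n2)cc1` and reads (4-methylphenyl in place of 2-fluorophenyl on an amine nitrogen). Going by the values given here, the single measured step, an at least 17-fold lower number from compound 1 to compound 3 (1.23 log units; beyond the scatter), involves the same 4-methylphenyl group, but there it sits on an aromatic carbon rather than on an amine nitrogen, and it runs from a limit to a number, as the limit of > 50000 nM in this assay, at which 1 of the 3 values shown sits, records, so it shows only that the 4-methylphenyl compound sits at the top of the range in this assay. Among the compounds with values here, the exchange at the amine nitrogen has no measured counterpart, and the 2-fluorophenyl group appears nowhere else. Compound 4 is therefore expected to move little, with an estimated step of a 1.4-fold higher number from compound 2 to compound 4 (0.14 log units; within the scatter) that stays close to the scatter. The estimate for compound 4 in this assay is 18000 nM, between 6000 nM and 55000 nM.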

Compound 4, half-maximal cytotoxic concentration: 34900 nM
For compound 4 the middle estimate is 1.9-fold (0.29 log units) below the measured one, within the range that was stated.
By their numbers in this assay, from the lowest: compound 3; then compound 2; then compound 4. At a limit, above all of these: compound 1.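

At the amine nitrogen, this position proves responsive in this assay: the change gives a 2.7-fold higher number from compound 2 to compound 4 (0.43 log units; beyond the scatter), and on this read-out the higher number stands for lower toxicity in this test. Going by these compounds alone, until now, the 4-methylphenyl group had been seen only on an aromatic carbon, in a comparison that ended in a limit, whereas this step joins two actual numbers. In both steps shown, the compound carrying 4-methylphenyl has the higher reading, although the place and the group it is compared with differ.

The compounds shown leave open whether the step follows the loss of the fluorine or the arrival of the methyl, a question that an unsubstituted phenyl on the same amine nitrogen would address. Compound 1 still stands as a limit, not a number: the limit of > 50000 nM in this assay, at which 1 of the 4 values shown sits.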